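The source may report more compounds than this note shows. Statements on the series, on what has been measured and on what is new or still open speak of the compounds shown alone.

Compound 1 `O=C(Nc1cccc(-n2cc(-c3ccncc3)c(-c3ccc(Cl)c(O)c3)n2)c1)Nc1cccc(C(F)(F)F)c1` and compound 2 `COc1cc(-c2nn(-c3cccc(NC(=O)c4cccc(C(F)(F)F)c4)c3)cc2-c2ccncc2)ccc1Cl` share a common core and differ in the linker to the trifluoromethyl-bearing ring and in the substituent pattern on the other outer ring. In a functional assay on CAKI-1 cells (Homo sapiens) for inhibition, read by sulforhodamine B assay, with a stated time of 48 h (on this read-out higher numbers stand for weaker inhibition of growth and lower numbers for stronger inhibition of growth), compound 1 gives 1750 nM. In this assay compound 2 gives 2010 nM; of the two numbers this is the higher one, but the gap to compound 1 lies within the scatter of repeated measurements, so the two compounds cannot be told apart on this read-out. Compound 3 `COc1cc(-c2nn(-c3cccc(NC(=O)c4ccc(Cl)c(C(F)(F)F)c4)c3)cc2-c2ccncc2)ccc1Cl` has not yet been measured. It differs from compound 2 by chloro in place of hydrogen on an aromatic carbon, so that the amide carries a 4-chloro-3-(trifluoromethyl)phenyl group in place of a 3-(trifluoromethyl)phenyl group. Among the measured compounds shown here, no measured pair shows what this change does in this assay. The step expected here is a 1.5-fold lower number from compound 2 to compound 3 (0.19 log units; within the scatter), a small one, with lower numbers somewhat more likely than higher ones, though a move beyond the scatter is not assured. Compound 3 is accordingly estimated at 1300 nM in this assay, with a range from 500 nM to 3500 nM.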

Compound 3, concentration for 50% growth inhibition: 2300 nM
Compound 3: middle estimate off by 1.8-fold (0.25 log units), on the low side; the measured number falls inside the stated range.
By their numbers in this assay, from the lowest: compounds 1, 2 and 3 (each within the scatter of the next).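

Going from 3-(trifluoromethyl)phenyl to 4-chloro-3-(trifluoromethyl)phenyl on the amide gives a 1.1-fold higher number from compound 2 to compound 3 (0.06 log units; within the scatter) in this assay, so a chloro on this aromatic carbon, ortho to a trifluoromethyl group and para to a large group, leaves the two compounds indistinguishable on this read-out. This is the first pair shown that differs in one place only, whereas compound 1 and compound 2 differ in both the linker and the other outer ring and could say nothing about this single position. Nothing available here bears on why the chloro leaves the read-out within the scatter.

Still open, as far as these compounds go, is whether a different group at this position, such as an amine or a carboxylic acid, would carry the number beyond the scatter in either direction. Also open, from the compounds shown here alone, is whether the chloro would read the same way on the linker of compound 1, since this one pair speaks only for the amide series of compound 2 and compound 3.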